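The source may hold more compounds than are shown below. What is called first, only, known or untested is meant among the compounds shown, and "the series" means these compounds.

Compound 1 `O=C(Nc1ccccc1OC(F)(F)F)Nc1n[nH]c2ccccc12` carries a urea on the shared core and, in a functional assay on Malme-3M cells (Homo sapiens) for inhibition, read by sulforhodamine B assay, with a stated time of 48 h (a higher number here means a weaker inhibitor of growth, a lower number a stronger inhibitor of growth), compound 1 gives 76900 nM. Compound 2 `O=C(Nc1ccc(Cc2ccccc2)cc1)Nc1nn(C(=O)Nc2ccc(Cc3ccccc3)cc2)c2ccccc12` carries two ureas on the same core. In this assay compound 2 reaches only a limit of the assay, > 100000 nM, one of the values at the limit described by the limit of > 100000 nM in this assay, at which 1 of the 3 values shown sits. Compound 3 `Nc1nn(C(=O)Nc2ccc(Cc3ccccc3)cc2)c2ccccc12` keeps a single urea together with a free amino group on the core, and in this assay compound 3 gives 19200 nM. Of the two numbers in hand, compound 3 has the lower one, and its distance from compound 1 lies beyond the usual scatter of the assay.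

Compound 4 `CCCCOc1ccc(NC(=O)n2nc(N)c3ccccc32)cc1` is the next compound in this line. Its structure differs from compound 3 in one place: butoxy in place of benzyl on an aromatic carbon. Within the data shown here, no step between measured compounds involves the same change, so the expectation rests on the structures alone. The group that enters and the group that leaves are both uncharged, and the estimated step from compound 3 to compound 4 in this assay is a 1.3-fold higher number from compound 3 to compound 4 (0.11 log units; within the scatter), a change that stays close to the scatter. For compound 4 the estimate in this assay is therefore 25000 nM, in the range from 8000 nM to 80000 nM.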

Compound 4, concentration for 50% growth inhibition: 14700 nM
For compound 4 the middle estimate is 1.7-fold (0.23 log units) above the measured one; low and high end bracket the measured number.
By their numbers in this assay, from the lowest: compounds 4 and 3 (each within the scatter of the next); then compound 1. At a limit, above all of these: compound 2.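

In this assay, among these compounds, the exchange of benzyl for butoxy, on an aromatic carbon para to a large group, comes to a 1.3-fold lower number from compound 3 to compound 4 (0.12 log units; within the scatter) and is the first step between two measured compounds that differ in one place. It shows that at this place the six-membered aromatic ring of carbon only in benzyl can give way to butoxy, a chain with no ring and one hydrogen-bond acceptor, while the numbers of the two compounds stay within the scatter of each other. No measured property of either group bears on this result, so nothing shown here accounts for how little the number moved.

On these data alone, whether a longer chain such as hexyloxy, an amine or a carboxylic acid at the same place would also leave the number in this assay within the scatter of compound 4 stays open. As far as these compounds go, what the free amino group on the core contributes stays open as well: compound 3 and compound 4 both carry it, so this pair cannot separate its part from that of the urea.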